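From 1H-indazol-5-yl to 1-methyl-1H-indol-5-yl

The source may hold more compounds than are shown below. What is called first, only, known or untested is meant among the compounds shown, and "the series" means these compounds.

Three compounds share one core and differ only in the group on a nitrogen on an aromatic ring. In a functional assay on K562 cells (Homo sapiens) for inhibition, read by trypan blue exclusion, with a stated time of 72 h (a lower number here means a stronger inhibitor, a higher number a weaker inhibitor), compound 1 `Cn1c(=O)c(S(=O)(=O)c2ccc(F)cc2F)cc2cnc(Nc3ccc4[nH]c(C(=O)O)cc4c3)nc21` gives 10000 nM, compound 2 `Cn1c(=O)c(S(=O)(=O)c2ccc(F)cc2F)cc2cnc(Nc3ccc4sccc4c3)nc21` gives 500 nM and compound 3 `Cn1c(=O)c(S(=O)(=O)c2ccc(F)cc2F)cc2cnc(Nc3ccc4[nH]ncc4c3)nc21` gives 50000 nM. Compound 3 therefore has the highest number of the three and is the weakest inhibitor here.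

Compound 4 `Cn1ccc2cc(Nc3ncc4cc(S(=O)(=O)c5ccc(F)cc5F)c(=O)n(C)c4n3)ccc21` carries 1-methyl-1H-indol-5-yl in place of 1H-indazol-5-yl on a nitrogen on an aromatic ring. For the measured compounds named here, no measured step tests this exact swap, but two steps leave from or arrive at the same group. One is a 100-fold higher number from compound 2 to compound 3 (2.00 log units; beyond the scatter), and the other, more modest, is a 5.0-fold higher number from compound 1 to compound 3 (0.70 log units; beyond the scatter). Both show that a group other than 1H-indazol-5-yl gave a lower number, so a lower number is expected here too, although how far it falls remains uncertain.

In this assay the expected change is a 33-fold lower number from compound 3 to compound 4 (1.52 log units; beyond the scatter), a large step. For compound 4 the estimate is 1500 nM, with an expected range from 300 nM to 10000 nM.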

Compound 4, half-maximal inhibitory concentration: 750 nM
Estimate against measurement, compound 4: 2.0-fold (0.30 log units) above; the range from low to high includes it.
By their numbers in this assay, from the lowest: compounds 2 and 4 (each within the scatter of the next); then compound 1; then compound 3.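

In this assay, replacing 1H-indazol-5-yl with 1-methyl-1H-indol-5-yl brings a 67-fold lower number from compound 3 to compound 4 (1.82 log units; beyond the scatter) and replacing 2-carboxy-1H-indol-5-yl with the same group brings a 13-fold lower number from compound 1 to compound 4 (1.12 log units; beyond the scatter) in the same direction. Against 1-benzothiophen-5-yl the new group shows a 1.5-fold higher number from compound 2 to compound 4 (0.18 log units; within the scatter) with no real separation, so at this place on a nitrogen on an aromatic ring, the low numbers in this set no longer belong to 1-benzothiophen-5-yl alone. The swap from 1H-indazol-5-yl changes the ring atoms, adds a methyl group and removes the hydrogen-bond donor all at once, and nothing available here explains why the number moves.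

On these data alone, whether the step belongs to the methyl group or to the ring atoms stays open; 1H-indol-5-yl, with a plain hydrogen on that ring nitrogen, would separate the two. Also open, as far as these compounds go, is what a longer chain or an amine on that ring nitrogen would do to the number.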